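Methoxycarbonyl Replaces Methoxy on the Aryl Amide

This account rests on a few compounds, and the source may have more. Where it says the series, first, only, none or still open, it means among the compounds named here.

compound 1 `COc1ccc(NC(=O)[C@@H]2CC=C(CCC=C(C)C)C[C@H]2c2ccccc2)cc1` > 23000 nM
compound 2 `CC(C)=CCCC1=CC[C@H](C(=O)N(C)O)[C@@H](c2ccccc2)C1` 2100 nM
compound 3 `CON(C)C(=O)[C@H]1CC=C(CCC=C(C)C)C[C@@H]1c1ccccc1` 300 nM

In an assay on isolated protein for inhibition of Apoptosis regulator Bcl-2 (Homo sapiens), read by fluorescence polarization, with stated times of 5 min and 10 min (on this read-out lower numbers stand for stronger inhibition and higher numbers for weaker inhibition), compound 1 gives > 23000 nM, which is a limit of the assay and not a number (the limit of > 23000 nM in this assay, at which 1 of the 3 values shown sits). Within the data shown here, compound 2 gives 2100 nM and compound 3 gives 300 nM; the one measured step, a 7.0-fold lower number from compound 2 to compound 3 (0.85 log units; beyond the scatter), concerns methyl in place of hydrogen on an oxygen and not the six-membered aromatic ring. Compound 4 `COC(=O)c1ccc(NC(=O)[C@@H]2CC=C(CCC=C(C)C)C[C@H]2c2ccccc2)cc1` differs from compound 1 by methoxycarbonyl in place of methoxy on an aromatic carbon. Among the measured compounds shown here, no measured pair shows this change, so nothing indicates its direction or size. Compound 4 is therefore expected to remain weak, near 20000 nM, within 5000 nM to 80000 nM. The expected step of an at least 1.1-fold lower number from compound 1 to compound 4 (0.06 log units; that floor lies within the scatter) is correspondingly small, and a limit rather than a number is quite likely.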

Compound 4, inhibition constant: > 23000 nM
Compound 4 ended at the assay's limit (the forecaster's own chance of this, stated with the estimate: 60%); at least 1.1-fold (0.06 log units) between middle value and limit.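

In this assay compound 4 gives > 23000 nM, which is a limit of the assay and not a number. Among these compounds, compound 1 also stands at a limit, so no step between these two compounds can be read: the limit of > 23000 nM in this assay, at which 2 of the 4 values shown sit. The compounds shown leave open whether methoxycarbonyl or methoxy on the aromatic carbon gives stronger inhibition.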